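A few compounds are considered here, and "the series" means these few. Any claim that something is new, unique, unknown or untested is made for them only; others in the source may bear on it.

Measured so far in an assay on Cerebral cortex (strain Sprague-Dawley) for displacement of a labelled ligand from Neuronal acetylcholine receptor; alpha4/beta2 (Rattus norvegicus); on this read-out higher numbers stand for weaker inhibition and lower numbers for stronger inhibition:

compound 1 `CN1CCC[C@H]1[C@@H]1COc2ccc(CO)cc2O1` gives 51000 nM
compound 2 `CN1CCC[C@H]1[C@@H]1COc2ccc(Br)cc2O1` gives 8100 nM
compound 3 `CN1CCC[C@@H]1[C@H]1COc2ccc(O)cc2O1` gives 3500 nM

Compound 3 has the lowest number of the three in this assay; compound 2 is nearest and compound 1 furthest, both steps beyond the scatter. The only step shown between compounds differing in one place is a 6.3-fold lower number from compound 1 to compound 2 (0.80 log units; beyond the scatter), a substituent exchange on the aromatic ring.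

Compound 4 `CN1CCC[C@H]1[C@H]1COc2ccc(O)cc2O1` is the next compound to be measured. Against compound 3, the difference is the two compounds have the same atoms and bonds and differ only in configuration as drawn: 1 of 2 stereo elements differ; a stereocentre at a saturated ring carbon is drawn R in compound 3 and S in compound 4. The hydroxyl substituent and the shared core are unchanged.

No measured step bears on this kind of change: the one shown step concerns a substituent exchange, not a change of configuration, so it gives no size to carry over. The series therefore gives no direct guide to the step from compound 3 to compound 4, and the estimate rests on the expectation that a change at a stereocentre of the saturated ring may move the number in either direction, most plausibly toward a higher number.

For compound 4 in this assay the estimate is 7000 nM, within a range of 1500 nM to 35000 nM; this is an expected step of a 2.0-fold higher number from compound 3 to compound 4 (0.30 log units; within the scatter), given with wide uncertainty.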

Compound 4, inhibition constant: 421 nM
Compound 4: middle estimate off by 17-fold (1.22 log units), on the high side; the measured number lies below the stated range.
By their numbers in this assay, from the lowest: compound 4; then compound 3; then compound 2; then compound 1.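

In this assay the stereocentre at a saturated ring carbon, drawn R in compound 3 and S in compound 4, proves to be a sensitive position: the change gives an 8.3-fold lower number from compound 3 to compound 4 (0.92 log units; beyond the scatter). The earlier step concerned only a substituent exchange on the aromatic ring, so it gave no size for a change of configuration, and this step now supplies one, with the S drawing giving the lower number while the hydroxyl stays in place. The shift can be assigned to configuration alone, because nothing else separates the two structures: the fact that compounds 3 and 4 differ only in the configuration as drawn.

Still open, going by these compounds, is whether the same change of configuration gives a step of similar size with bromo or hydroxymethyl in place of the hydroxyl, and what a change at the second stereo element, which compound 3 and compound 4 share, would do. Also open, on these data alone, is how an amine or a carboxylic acid in place of the hydroxyl would read in this assay on the configuration of compound 4.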